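Moving the fluorine on the amide-bound phenyl ring

A few compounds are considered here, and "the series" means these few. Any claim that something is new, unique, unknown or untested is made for them only; others in the source may bear on it.

Compound 1 `Cc1cc(C)cc(NC(=O)CN2CCC(c3cccc[n+]3[O-])CC2)c1`: 52 nM
Compound 2 `O=C(CN1CCC(c2cccc[n+]2[O-])CC1)Nc1cccc(F)c1`: 160 nM
Compound 3 `O=C(CN1CCC(c2cccc[n+]2[O-])CC1)Nc1cc(Cl)cc(Cl)c1`: 160 nM

Of the compounds shown here, three sharing one core have been tested in a functional assay on HEK293 cells for agonist activity at D(4) dopamine receptor (Homo sapiens), read by FLIPR; on this read-out higher numbers stand for an effect only at larger amounts of compound and lower numbers for an effect already at smaller amounts; they differ only in the aryl group on the amide-type nitrogen. Compound 3 stands level with compound 2, the two together giving the highest numbers of the three, and compound 1 gives the lowest, seen in a 3.1-fold higher number from compound 1 to compound 3 (0.49 log units; beyond the scatter). Compound 4 `O=C(CN1CCC(c2cccc[n+]2[O-])CC1)Nc1ccc(F)cc1` is the next step: 4-fluorophenyl in place of 3,5-dichlorophenyl on an amide-type nitrogen. Among the compounds with values here, no measured pair shows this particular exchange. The closest guide is no change at the digits printed from compound 2 to compound 3 (within the scatter), where trading one halogen pattern on that phenyl ring for another made no difference, while a 3.1-fold higher number from compound 1 to compound 2 (0.49 log units; beyond the scatter) and a 3.1-fold higher number from compound 1 to compound 3 (0.49 log units; beyond the scatter) show that only the dimethyl pattern has moved the number beyond the scatter. A single fluorine in a new position is therefore expected to leave the number close to that of compound 3, with the step of a 1.1-fold higher number from compound 3 to compound 4 (0.03 log units; within the scatter) expected to stay within the scatter. For compound 4 the estimate is 170 nM, between 60 nM and 500 nM.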

Compound 4, half-maximal effective concentration: 85 nM
Compound 4: middle estimate off by 2.0-fold (0.30 log units), on the high side, within the range that was stated.
By their numbers in this assay, from the lowest: compounds 1, 4, 2 and 3 (each within the scatter of the next, the first and the last beyond it).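

In this assay, within the data shown here, the 4-fluorophenyl group cannot be told apart from either earlier halogen-bearing ring (a 1.9-fold lower number from compound 2 to compound 4 (0.27 log units; within the scatter); a 1.9-fold lower number from compound 3 to compound 4 (0.27 log units; within the scatter)), so this is a first look at shifting a fluorine around the ring, and the shift gives no change that can be read. It also stays within the scatter of the 3,5-dimethylphenyl group (a 1.6-fold higher number from compound 1 to compound 4 (0.21 log units; within the scatter)), so the clear gap between the dimethyl ring and the halogen rings holds only for compound 2 and compound 3, with compound 4 going against it. Nothing on hand offers a reason for these numbers.

Still open, going by these compounds, is how a single methyl group on this phenyl ring compares with the single fluorine. A 3,5-difluorophenyl group, or a phenyl ring carrying an amine or a carboxylic acid, could also show whether this position tolerates much larger changes.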